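The compounds below may be only part of what the source reports. "The series", "measured", "known", "first", "only" and "open" are said of these compounds alone.

In a functional assay on a cell-free system (Platelet, plasma, Homo sapiens) for inhibition (on this read-out lower numbers stand for stronger inhibition and higher numbers for weaker inhibition), three compounds have been measured, all at high numbers. Compound 1 `COc1ccc(NC(=O)C2CCCNC2)cc1` gives 983000 nM, compound 2 `O=C(Nc1cccc(OCc2ccc(-c3ccccc3)cc2)c1)C1CCCNC1` gives 153000 nM and compound 3 `N=C(N)N1CCCC(C(=O)Nc2cccc(OCc3ccc(F)cc3)c2)C1` gives 274000 nM. Compound 3 thus lies within the usual scatter of compound 2 and beyond the scatter on the stronger side of compound 1.

Compound 4 `N=C(N)N1CCCC(C(=O)Nc2cccc(OCc3ccc(-c4ccccc4)cc3)c2)C1` differs from compound 3 in one place: phenyl in place of fluoro on an aromatic carbon. Going by the values given here, no pair of measured compounds isolates this change, so the evidence is indirect. Compound 2 also bears that phenyl and gives 153000 nM, a value that offers only a weak hint of modestly stronger inhibition. In this assay the expected change is a 2.3-fold lower number from compound 3 to compound 4 (0.36 log units; beyond the scatter), a small step toward stronger inhibition that may barely clear the scatter. For compound 4 the estimated value is 120000 nM, with an expected range from 40000 nM to 300000 nM.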

Compound 4, half-maximal inhibitory concentration: 1000000 nM
Compound 4: the middle estimate sits 8.3-fold (0.92 log units) below what was measured; measured number above the stated range.
By their numbers in this assay, from the lowest: compounds 2 and 3 (each within the scatter of the next); then compounds 1 and 4 (each within the scatter of the next).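

In this assay, the step at this aromatic carbon, para to a large group, runs toward weaker inhibition: phenyl in place of fluoro gives a 3.6-fold higher number from compound 3 to compound 4 (0.56 log units; beyond the scatter). With the phenyl present, the ring amine nitrogen can also be read directly, and the group of 3 heavy atoms in place of a hydrogen atom gives a 6.5-fold higher number from compound 2 to compound 4 (0.82 log units; beyond the scatter), so this change too goes toward weaker inhibition. No measurement at hand accounts for either step.

The compounds shown leave open whether the step on the amine nitrogen would hold with fluoro rather than phenyl at the aromatic carbon. They also leave open how a chloro or a methoxy at that same carbon would read, and how an acetyl on the amine nitrogen would compare.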